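Dimethylamino Substitution on the Phenyl Ring of Compound 2

A few compounds are considered here, and "the series" means these few. Any claim that something is new, unique, unknown or untested is made for them only; others in the source may bear on it.

The series is built on a shared core carrying two methoxy-hydroxy-styryl arms. Compound 1 `COc1cc(/C=C/C(=O)C2=C(/C=C/c3ccc(O)c(OC)c3)NC(=O)NC2c2ccccc2O)ccc1O` bears an oxo group in its ring and a hydroxyphenyl substituent; in a functional assay, with a stated time of 20 min, tested at 50 uM (on this read-out higher numbers stand for a stronger effect at the one concentration tested and lower numbers for a weaker effect), compound 1 gives 88.9%. Compound 2 `COc1cc(/C=C/C(=O)C2=C(/C=C/c3ccc(O)c(OC)c3)NC(=S)NC2c2ccccc2)ccc1O` carries a thioxo group and an unsubstituted phenyl; in this assay compound 2 gives 48%. Among the measured compounds shown here, compound 2 thus stands lowest of the two numbers so far, and its nearest neighbour, compound 1, lies higher by an amount beyond the scatter. Compounds 1 and 2 differ in two places. For the measured compounds named here, the two values show only that the pair sits far apart.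

Compound 3 `COc1cc(/C=C/C(=O)C2=C(/C=C/c3ccc(O)c(OC)c3)NC(=S)NC2c2ccc(N(C)C)cc2)ccc1O` keeps the thioxo core of compound 2 and differs from it in one place: dimethylamino in place of hydrogen on an aromatic carbon. Going by the values given here, no measured step of this kind exists in the data, so the direction is open. The step from compound 2 to compound 3 is expected to be small, a number 4 percentage points higher from compound 2 to compound 3 (within the scatter), within or only just beyond the scatter. In this assay compound 3 is therefore estimated at 52%, with a range from 30% to 75%.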

Compound 3, a percentage reported as activity, at one concentration (the size of the read-out at that concentration, not a potency): 89.5%
Compound 3: middle estimate off by 37.5 percentage points, on the low side; measured number outside the range, above it.
By their numbers in this assay, from the lowest: compound 2; then compounds 1 and 3 (each within the scatter of the next).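

Among the compounds shown here, the step from hydrogen to dimethylamino is the first single change that can be read, and in this assay it amounts to a number 41.5 percentage points higher from compound 2 to compound 3 (beyond the scatter), a large step. It shows that, on the thioxo core, the aromatic carbon para to a large group is a sensitive place: this one substitution, with the rest of the structure unchanged, moves the read-out well past the usual scatter, and so a single substituent here can matter as much as anything yet seen in the series. Nothing in the data explains why the read-out moves this far.

The compounds shown do not tell whether this step belongs to dimethylamino in particular or would also appear with another group at this place, such as a primary amine, a morpholine ring or a carboxylic acid. They also leave open whether dimethylamino at the same place would give a step of like size on the oxo core, or with a hydroxyl group already on the phenyl ring.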